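Glycine analogue of a furoxan–amide hybrid: expected cytotoxicity

The source may hold more compounds than are shown below. What is called first, only, known or untested is meant among the compounds shown, and "the series" means these compounds.

Measured compounds:
compound 1 `CC(C)=CCC/C(C)=C/CC/C(C)=C/CSc1ccccc1C(=O)N[C@@H](C)C(=O)OCC#CCOc1no[n+]([O-])c1S(=O)(=O)c1ccccc1`: 11400 nM
compound 2 `CC(C)=CCC/C(C)=C/CC/C(C)=C/CSc1ccccc1C(=O)N[C@@H](C)C(=O)OCCCCOc1no[n+]([O-])c1S(=O)(=O)c1ccccc1`: 44600 nM
compound 3 `CC(C)=CCC/C(C)=C/CC/C(C)=C/CSc1ccccc1C(=O)NCC(=O)OCCCCOc1no[n+]([O-])c1S(=O)(=O)c1ccccc1`: > 50000 nM

In a functional assay on SGC-7901 cells (Homo sapiens) for cytotoxicity, read by MTT assay, with a stated time of 48 h (on this read-out lower numbers stand for stronger inhibition and higher numbers for weaker inhibition), compound 1 gives 11400 nM, the lowest of the two numbers. Compound 2 gives 44600 nM in this assay. The value of compound 3 in this assay is a limit, not a number; it sits at the limit of > 50000 nM in this assay, at which 1 of the 3 values shown sits. How the core of compound 1 differs from that of compound 2 is not broken down here. Compound 3 differs from compound 2 by hydrogen in place of methyl on a saturated chain carbon bound to an amide-type nitrogen and a carbonyl carbon. That change gave an at least 1.1-fold higher number from compound 2 to compound 3 (0.04 log units; that floor lies within the scatter).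

Compound 4 `CC(C)=CCC/C(C)=C/CC/C(C)=C/CSc1ccccc1C(=O)NCC(=O)OCC#CCOc1no[n+]([O-])c1S(=O)(=O)c1ccccc1` is not yet measured. It differs from compound 1 by hydrogen in place of methyl on a saturated chain carbon bound to an amide-type nitrogen and a carbonyl carbon, the same change as from compound 2 to compound 3. Resting on the step from compound 2 to compound 3, compound 4 is expected to weaken by a 2.2-fold higher number from compound 1 to compound 4 (0.34 log units; beyond the scatter). Compound 4 is thus estimated at 25000 nM, between 11000 nM and 50000 nM.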

Compound 4, half-maximal inhibitory concentration: 11400 nM
Compound 4: middle estimate off by 2.2-fold (0.34 log units), on the high side; measured number inside the range.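

In this assay, hydrogen in place of methyl on a saturated chain carbon bound to an amide-type nitrogen and a carbonyl carbon gave no change at the digits printed from compound 1 to compound 4 (within the scatter). Set beside the same change on the other core, this shows no loss on the core of compound 1, but it does not establish that the change acts alike on both cores: the same change on two cores in this assay, an at least 1.1-fold higher number (0.04 log units; that floor lies within the scatter) from compound 2 to compound 3 and no change at the digits printed (within the scatter) from compound 1 to compound 4; the limit leaves it open whether they differ. From the compounds shown here alone, compound 3 stands at a limit and not at a number, so the size of its step stays unknown: the limit of > 50000 nM in this assay, at which 1 of the 4 values shown sits.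

The compounds shown leave open what a larger group in this place, such as isopropyl or benzyl, would do on either core. They also leave open how a hydroxymethyl group there would read in this assay.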